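The compounds below may be only part of what the source reports. "The series", "measured", "known", "first", "only" and "open" are said of these compounds alone.

Series in a functional assay on NCI-H460 cells (Homo sapiens) for antiproliferative activity, read by MTT assay, with a stated time of 48 h; on this read-out higher numbers stand for weaker inhibition and lower numbers for stronger inhibition:
- Compound 1 `COc1cccc(-c2nc3cccc(-c4cc(OC)c(OC)c(OC)c4)c3o2)c1`: > 25000 nM (a limit)
- Compound 2 `COc1cc(-c2cccc3nc(-c4ccc5cc[nH]c5c4)oc23)cc(OC)c1OC`: 24 nM
- Compound 3 `COc1cc(-c2cccc3nc(-c4ccco4)oc23)cc(OC)c1OC`: not yet measured

Going by the values given here, compound 2, at 24 nM, holds the only true number in this assay so far. Among the compounds with values here, the one other reading, for compound 1, is > 25000 nM, and it is a limit.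

The next change goes from compound 2 to compound 3: furan-2-yl in place of 1H-indol-6-yl on an aromatic carbon.

Within the data shown here, one measured step bears on this, since it involves the same 1H-indol-6-yl group on the same carbon, here arriving rather than leaving: an at least 1000-fold lower number from compound 1 to compound 2 (3.01 log units; beyond the scatter). That step ends at a limit on one side, so its true size is open, and it tests another group than furan-2-yl. A clear move towards weaker inhibition is still expected once the 1H-indol-6-yl group leaves, given that step, though probably not all the way to the limit.

The expected change is a 100-fold higher number from compound 2 to compound 3 (2.02 log units; beyond the scatter), which is large and towards a higher number. For compound 3 the estimated value is 2500 nM, with an expected range of 200 nM to 25000 nM.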

Compound 3, half-maximal inhibitory concentration: 2600 nM
Estimate against measurement, compound 3: 1.0-fold (0.02 log units) below; measured number inside the range.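

In this assay, the change at this aromatic carbon, next to the ring nitrogen and next to the ring oxygen, shows that a different five-membered aromatic ring does not keep the activity of compound 2: furan-2-yl in place of 1H-indol-6-yl gives a 110-fold higher number from compound 2 to compound 3 (2.03 log units; beyond the scatter). Furan-2-yl in place of 3-methoxyphenyl gives an at least 9.6-fold lower number from compound 1 to compound 3 (0.98 log units; beyond the scatter), so this position also separates two groups that both fall well short of 1H-indol-6-yl, with furan-2-yl the better of the two in this series. As far as these compounds go, the reading for compound 1 is a limit, and the size of any step starting from it stays open: the limit of > 25000 nM in this assay, at which 1 of the 3 values shown sits.

The step from 1H-indol-6-yl to furan-2-yl removes the six-membered aromatic ring and the hydrogen-bond donor together and also swaps the hetero atom, so the compounds shown do not tell which of these changes accounts for the loss. From the compounds shown here alone, a benzofuran-6-yl group, with a ring oxygen in place of the ring nitrogen-hydrogen, or a pyrrol-2-yl group would pull these apart, and the effect of attaching the indole through another of its carbons also remains open.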